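The source may report more compounds than this note shows. Statements on the series, on what has been measured and on what is new or still open speak of the compounds shown alone.

In an assay on Cerebral cortex for binding affinity to adenosine receptor A1 (Cavia porcellus), read by radioligand binding (a higher number here means a weaker inhibitor, a lower number a stronger inhibitor), compound 1 `C=CCn1c(=O)c2[nH]cnc2n(CCC)c1=O` gives 1700 nM, while compound 2 `CCCn1c(=O)n(CCC(N)=O)c(=O)c2[nH]cnc21` gives 31500 nM. Among the measured compounds shown here, the single change between them is carbamoylmethyl in place of vinyl on a saturated chain carbon bound to an aromatic nitrogen, and it produced a 19-fold higher number from compound 1 to compound 2 (1.27 log units; beyond the scatter). Among the two numbers so far, compound 2 holds the highest, with compound 1 its only and distant neighbour.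

Compound 3 `CCCn1c(=O)n(CC(C)=O)c(=O)c2[nH]cnc21` differs from compound 2 by acetyl in place of carbamoylmethyl on a saturated chain carbon bound to an aromatic nitrogen. For the measured compounds named here, only one measured step bears on this change, the one that brought carbamoylmethyl in, a 19-fold higher number from compound 1 to compound 2 (1.27 log units; beyond the scatter), which was large. Going by the values given here, the present change takes carbamoylmethyl out again, so some recovery toward compound 1 seems plausible, but acetyl is not vinyl, and no measured step shows what acetyl does here. Compound 3 is therefore expected to show an improvement of a 3.2-fold lower number from compound 2 to compound 3 (0.50 log units; beyond the scatter). The estimate for compound 3 in this assay is 10000 nM, with a range from 3000 nM to 35000 nM.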

Compound 3, inhibition constant: 11400 nM
Compound 3: middle estimate off by 1.1-fold (0.06 log units), on the low side; low and high end bracket the measured number.
By their numbers in this assay, from the lowest: compound 1; then compound 3; then compound 2.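

In this assay, acetyl in place of carbamoylmethyl on a saturated chain carbon bound to an aromatic nitrogen gave a 2.8-fold lower number from compound 2 to compound 3 (0.44 log units; beyond the scatter) and so won back part of the earlier loss, with the entering group counting 0 hydrogen-bond donors against 1 for the group that left. The recovery was only partial, since a 6.7-fold higher number from compound 1 to compound 3 (0.83 log units; beyond the scatter) remains, and both groups holding a carbonyl at this place therefore read weaker than vinyl. Nothing measured here gives a reason for either step.

Acetyl differs from carbamoylmethyl in both its donor count and its heavy-atom count, so the compounds shown cannot separate those two differences. As far as these compounds go, how an amine, a carboxylic acid or a longer chain would read at this place also remains open.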